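A few compounds are considered here, and "the series" means these few. Any claim that something is new, unique, unknown or untested is made for them only; others in the source may bear on it.

Compound 1: `COc1ccc(CNC(=O)c2cc(-c3cc(C)cc(C)c3)cnc2-c2cccnc2)cc1`, in an assay on isolated protein for displacement of a labelled ligand from Orexin receptor type 2 (Homo sapiens), read by scintillation counting, with a stated time of 60 min (a higher number here means a weaker inhibitor, a lower number a stronger inhibitor), compound 1 gives 22 nM.
Compound 2: `Cc1cc(C)cc(-c2cnc(-c3cccnc3)c(C(=O)NCc3ccc(F)c(C)c3)c2)c1`, in this assay compound 2 gives 18 nM.
Compound 3: `COc1ccc(CNC(=O)c2cc(-c3cc(C)cc(C)c3)cnc2-c2cccnc2)cc1OC`, in this assay compound 3 gives 0.7 nM.

Among the three measured compounds, compound 3 gives the lowest number, and its separation from the other two is large: a 31-fold lower number from compound 1 to compound 3 (1.50 log units; beyond the scatter) and a 26-fold lower number from compound 2 to compound 3 (1.41 log units; beyond the scatter). The step between the other two is small: a 1.2-fold lower number from compound 1 to compound 2 (0.09 log units; within the scatter). All three of these steps concern the group on the saturated chain carbon bound to the amide-type nitrogen.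

Compound 4 is `COc1ccc(CNC(=O)c2cc(-c3cc(F)cc(F)c3)cnc2-c2cccnc2)cc1OC`. It differs from compound 3 at a different position: 3,5-difluorophenyl in place of 3,5-dimethylphenyl on an aromatic carbon, on an aromatic carbon of a six-membered aromatic ring with one nitrogen, two atoms from the ring nitrogen, para to a pyridin-3-yl group. Among the compounds with values here, none of the measured steps touches this position, so nothing in the data shows how the assay responds to a change here. The expectation for compound 4 therefore rests only on the strong starting point of compound 3 and carries a wide range; a modest step is expected, a 2.9-fold higher number from compound 3 to compound 4 (0.46 log units; beyond the scatter), with no firm direction. Compound 4 is estimated at 2 nM, within the range 0.4 nM to 10 nM.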

Compound 4, inhibition constant: 8.3 nM
The estimate for compound 4 lay 4.2-fold (0.62 log units) below the measured number, and the stated range covers the measured number.
By their numbers in this assay, from the lowest: compound 3; then compound 4; then compounds 2 and 1 (each within the scatter of the next).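

Within the data shown here, this is the first look at the aromatic carbon para to a pyridin-3-yl group, and it shows that this assay responds strongly to a change there: 3,5-difluorophenyl in place of 3,5-dimethylphenyl gives a 12-fold higher number from compound 3 to compound 4 (1.07 log units; beyond the scatter). The two groups have the same count of heavy atoms, the same six-membered aromatic ring of carbon only, and no hydrogen-bond donors or acceptors, yet exchanging two methyl groups for two fluorine atoms is enough to produce a large step. Nothing measured here explains why this exchange matters so much.

This single pair cannot tell whether the step comes from adding fluorine or from removing methyl; an unsubstituted phenyl, or a phenyl carrying chlorine atoms or methoxy groups, would help separate the two. From the compounds shown here alone, it also remains open whether the step would be the same size with 4-methoxyphenyl or 4-fluoro-3-methylphenyl on the chain carbon, as the 3,5-difluorophenyl group appears here only with 3,4-dimethoxyphenyl.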